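A Smaller Sulfur-Bearing Group Replaces the Dicyanoethenyl Group

This account rests on a few compounds, and the source may have more. Where it says the series, first, only, none or still open, it means among the compounds named here.

Compound 1 `CCC(=O)c1ccc2c(c1)C(n1ccccc1=O)=CC(C)(C)O2` gives 6.63 in a functional assay (aorta) with Rattus norvegicus as the target; on this read-out lower numbers stand for lower potency and higher numbers for higher potency (the scale is a negative logarithm).
Compound 2 `CC1(C)C=C(n2ccccc2=O)c2cc(C(=N)NO)ccc2O1` gives 5.99 in this assay.
Compound 3 `CC1(C)C=C(n2ccccc2=O)c2cc(C=C(C#N)C#N)ccc2O1` gives 6.95 in this assay.

Compound 3 stands highest of the three, with compound 1 nearest and compound 2 furthest below it. Compound 4 `CC1(C)C=C(n2ccccc2=O)c2cc(C(=N)S)ccc2O1` is not yet measured; it differs from compound 3 in one place: a group of 3 heavy atoms (1 carbon, 1 nitrogen, 1 sulfur; no ring) in place of a group of 6 heavy atoms (4 carbon, 2 nitrogen; no ring), on an aromatic carbon. For the measured compounds named here, two measured steps bear on this change: a number 0.96 log units higher from compound 2 to compound 3 (beyond the scatter) and a number 0.32 log units higher from compound 1 to compound 3 (beyond the scatter). The group that enters in compound 4 is small and carries hydrogen-bond donors, as does the group on compound 2, so the step is expected to run back toward compound 2. Compound 4 is therefore expected to lose potency, with an estimated step of a number 0.75 log units lower from compound 3 to compound 4 (beyond the scatter), giving an estimated 6.2 (range 5.7 to 6.7).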

Compound 4, logarithm of the reciprocal of the active concentration, log(1/C): 6.21
Estimate against measurement, compound 4: 0.01 log units below; measured number inside the range.
By their numbers in this assay, from the lowest: compounds 2 and 4 (each within the scatter of the next); then compound 1; then compound 3.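

In this assay, the small sulfur-bearing group does not keep the level of the 2,2-dicyanoethenyl group (a number 0.74 log units lower from compound 3 to compound 4 (beyond the scatter)) and also falls short of propanoyl (a number 0.42 log units lower from compound 1 to compound 4 (beyond the scatter)). Exchanging hydroxyamino for sulfanyl on the carbon with a double bond to nitrogen gives no difference that can be told from the scatter (a number 0.22 log units higher from compound 2 to compound 4 (within the scatter)). On this aromatic carbon, the two groups with that carbon therefore stand apart from compound 1 and compound 3 but not from each other.

On these data alone, whether an amine or a carboxylic acid here would reach the level of compound 3 remains open. Nothing shown explains these differences.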